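A few compounds are considered here, and "the series" means these few. Any claim that something is new, unique, unknown or untested is made for them only; others in the source may bear on it.

Compound 1 `CC(O)n1cnc2c(Cl)nc(I)nc21` — > 500000 nM
Compound 2 `CC(=O)OCCOn1cnc2c(S)nc(N)nc21` — > 500000 nM
Compound 3 `CC(=O)OCCOn1cnc2c(S)nc(F)nc21` — > 500000 nM

All three were tested in a functional assay on HT-29 cells (Homo sapiens) for inhibition; a higher number here means a weaker inhibitor, a lower number a stronger inhibitor. Each of these values is a limit of the assay rather than a measured number, and the limit of > 500000 nM in this assay, at which 3 of the 3 values shown sit, shows that every value reported so far sits at that same limit. Compound 3 therefore stands at the limit, with no number of its own. For the measured compounds named here, the only comparison between measured compounds, a step that the two limits leave unreadable from compound 2 to compound 3, links two limits and cannot be read in size or direction.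

Compound 4 `OCCOn1cnc2c(S)nc(F)nc21` differs from compound 3 by hydrogen in place of acetyl on an oxygen on a saturated carbon. Going by the values given here, no measured step touches this kind of change, and the one step that exists is unreadable, so there is no basis for expecting a shift beyond the scatter in either direction. The most that can be said is that compound 3 gave no number, and compound 4 is expected, most likely, to give a limit as well. The estimate for compound 4 is 500000 nM, with a range from 100000 nM to 2000000 nM. This expected estimate corresponds to a step of a number no higher from compound 3 to compound 4 (the limit leaves the size open).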

Compound 4, half-maximal inhibitory concentration: > 500000 nM
Compound 4 was reported as a limit; the forecaster's own chance of this, stated with the estimate: 80%; the middle value lies on the limit itself.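

Compound 3 and compound 4 each gave only a limit, so the change from acetyl to hydrogen yields no readable step. The compounds shown leave open which structure, if any, would give an actual number in this assay, since all share one result: the limit of > 500000 nM in this assay, at which 4 of the 4 values shown sit.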